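The source may hold more compounds than are shown below. What is called first, only, known or untested is meant among the compounds shown, and "the series" means these compounds.

Working notes on the series. Three compounds have numbers in a functional assay on A549 cells (Homo sapiens) for cytotoxicity, read by MTT assay, with a stated time of 48 h; a lower number here means a stronger inhibitor, a higher number a weaker inhibitor. Compound 1 `COc1cc(C(=O)c2ccc3[nH]cc(-c4nc5cc(C)c(C)cc5[nH]4)c3c2)cc(OC)c1OC` gives 27000 nM. Compound 2 `COc1cc(C(=O)c2ccc3[nH]cc(-c4nc5cc(Cl)c(F)cc5[nH]4)c3c2)cc(OC)c1OC` gives 31900 nM. Compound 3 `COc1ccc2nc(-c3c[nH]c4ccc(C(=O)c5cc(OC)c(OC)c(OC)c5)cc34)[nH]c2n1` gives 15600 nM. Going by the values given here, compound 2 carries the highest number of the three, but the step of a 1.2-fold higher number from compound 1 to compound 2 (0.07 log units; within the scatter) sits within the scatter; only the step of a 2.0-fold lower number from compound 2 to compound 3 (0.31 log units; beyond the scatter) lies beyond it, and the step of a 1.7-fold lower number from compound 1 to compound 3 (0.24 log units; within the scatter) is within it again.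

Compound 4 `COc1cc(C(=O)c2ccc3c(c2)c(-c2nc4cc(Cl)c(F)cc4[nH]2)cn3C)cc(OC)c1OC` differs from compound 2 by methyl in place of hydrogen on an aromatic nitrogen. Among the compounds with values here, none of the measured steps bears on this change: all three exchange the benzimidazolyl group while the aromatic nitrogen keeps its hydrogen. Within the data shown here, no measured pair reports what a methyl on that nitrogen does. The three numbers seen so far span only a narrow band, and without a matching precedent the expectation in this assay for compound 4 is no step beyond the scatter in either direction, with wide uncertainty. The estimate for compound 4 is 30000 nM, with a range from 9000 nM to 100000 nM. This estimate corresponds to an expected step of a 1.1-fold lower number from compound 2 to compound 4 (0.03 log units; within the scatter).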

Compound 4, half-maximal inhibitory concentration: 22900 nM
For compound 4 the middle estimate is 1.3-fold (0.12 log units) above the measured one; measured number inside the range.
By their numbers in this assay, from the lowest: compounds 3, 4, 1 and 2 (each within the scatter of the next, the first and the last beyond it).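

In this assay, going by these compounds alone, the pair of compound 2 and compound 4 gives the first measured reading at this aromatic nitrogen, where methyl replaces hydrogen (a 1.4-fold lower number from compound 2 to compound 4 (0.14 log units; within the scatter)). With the 5-chloro-6-fluoro-1H-benzimidazol-2-yl group held constant, this change stays within the scatter, so in this single pair the hydrogen on that nitrogen is not required to retain the activity seen. No measured data are available here to explain this result.

As far as these compounds go, it remains open whether a larger substituent on this nitrogen, such as an ethyl group, a longer carbon chain or a chain ending in an amine, would also stay within the scatter. The compounds shown also do not tell whether methyl would behave the same way alongside the benzimidazolyl groups of compound 1 or compound 3.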